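Acyl variation on the amide of the catechol thiadiazoles

A few compounds are considered here, and "the series" means these few. Any claim that something is new, unique, unknown or untested is made for them only; others in the source may bear on it.

Three compounds in this series have numbers in an ADME assay on MRC5 cells (Homo sapiens) for cytotoxicity, read by MTT assay, with a stated time of 72 h; a higher number here means a weaker inhibitor, a lower number a stronger inhibitor. Compound 1 `O=C(Nc1nnc(-c2cccc(O)c2O)s1)C1CCCCC1` gives 70300 nM, compound 2 `CC(=O)Nc1nnc(-c2ccc(O)c(O)c2)s1` gives 58600 nM, and compound 3 `O=C(COc1ccccc1)Nc1nnc(-c2cccc(O)c2O)s1` gives 33900 nM. Compound 2 sits in the middle of the three numbers: compound 1 is within the usual scatter of it, and compound 3 is also within the scatter of it, so no order among these three can be read with confidence. Going by the values given here, the one step that changes a single place, a 2.1-fold lower number from compound 1 to compound 3 (0.32 log units; beyond the scatter), is the only measured change of the group on the carbonyl carbon, and it is modest.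

Compound 4 `O=C(Nc1nnc(-c2ccc(O)c(O)c2)s1)c1ccccc1` differs from compound 2 in the same place, on the carbonyl carbon: phenyl in place of methyl on a carbonyl carbon. Among the compounds with values here, the step from compound 1 to compound 3 is the nearest guide, since it too exchanges the group on the carbonyl carbon, but it swaps one large group for another, whereas here a small group gives way to a larger one, and no measured pair shows that kind of exchange. The expectation is therefore a step of about the size seen for a 2.1-fold lower number from compound 1 to compound 3 (0.32 log units; beyond the scatter) or smaller, in the lowering direction, with a good chance that it falls within the scatter. Compound 4 is estimated at 40000 nM, with a range from 18000 nM to 90000 nM; the expected step is a 1.5-fold lower number from compound 2 to compound 4 (0.17 log units; within the scatter).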

Compound 4, half-maximal inhibitory concentration: 27400 nM
For compound 4 the middle estimate is 1.5-fold (0.16 log units) above the measured one, within the range that was stated.
By their numbers in this assay, from the lowest: compounds 4, 3, 2 and 1 (each within the scatter of the next, the first and the last beyond it).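

In this assay, going by these compounds alone, phenyl in place of methyl on a carbonyl carbon gives a 2.1-fold lower number from compound 2 to compound 4 (0.33 log units; beyond the scatter); this is the first measured step in which a small group at this place gives way to a larger one, and the entering group adds one six-membered aromatic ring of carbon only, with no hydrogen-bond donors or acceptors. Set beside a 2.1-fold lower number from compound 1 to compound 3 (0.32 log units; beyond the scatter), it makes two modest steps at this place, on two different cores, both running towards a lower number with an aromatic ring in the entering group; neither of the two pairs goes against this, but two pairs are a thin base for a pattern. Nothing available bears on what lies behind the step.

As far as these compounds go, whether the lower number follows the size of the entering group or the presence of an aromatic ring stays open, and a longer chain without a ring, put at this same place on the core of compound 2, would separate the two. How a group carrying an amine or a carboxylic acid would stand against compound 4 at this place is open as well.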